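A few compounds are considered here, and "the series" means these few. Any claim that something is new, unique, unknown or untested is made for them only; others in the source may bear on it.

In a functional assay on SK-BR-3 cells (Homo sapiens) for antiproliferative activity (a higher number here means a weaker inhibitor, a lower number a stronger inhibitor), compound 3 `CC(C)=CCc1cc(C(=O)Nc2cc3ccc(OCCCNC(C)C)c(C)c3oc2=O)ccc1O` gives 750 nM and compound 1 `CC(C)=CCc1cc(C(=O)Nc2cc3ccc(OCC4CCCNC4)c(C)c3oc2=O)ccc1O` gives 600 nM as values within the scatter of each other. Compound 2 `CC(C)=CCc1cc(C(=O)Nc2cc3ccc(OCCCN4CCCCC4)c(C)c3oc2=O)ccc1O` gives > 50000 nM as a limit of the assay. Compound 4 `CC(C)=CCc1cc(C(=O)Nc2cc3ccc(OCCCNC(C)(C)C)c(C)c3oc2=O)ccc1O` carries (tert-butyl)amino in place of isopropylamino, the change being methyl in place of hydrogen on a saturated chain carbon bound to an amine nitrogen and two saturated chain carbons on a saturated chain carbon bound to an amine nitrogen and two saturated chain carbons. Within the data shown here, two measured steps bear on it: a 1.3-fold higher number from compound 1 to compound 3 (0.10 log units; within the scatter) stays small, while an at least 66-fold lower number from compound 2 to compound 3 (1.82 log units; beyond the scatter) is large and involves loss of piperidin-1-yl. Compound 4 has no piperidin-1-yl, so no large step is expected in this assay, at most a slight move towards a higher number. The estimated step is a 1.3-fold higher number from compound 3 to compound 4 (0.12 log units; within the scatter) overall. Compound 4 is expected at 1000 nM within an estimated range of 300 nM to 4000 nM overall.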

Compound 4, half-maximal inhibitory concentration: 660 nM
For compound 4 the middle estimate is 1.5-fold (0.18 log units) above the measured one, and the stated range covers the measured number.
By their numbers in this assay, from the lowest: compounds 1, 4 and 3 (each within the scatter of the next). At a limit, above all of these: compound 2.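

In this assay, methyl in place of hydrogen on this saturated chain carbon, turning isopropylamino into (tert-butyl)amino, produces no change beyond the scatter (a 1.1-fold lower number from compound 3 to compound 4 (0.06 log units; within the scatter)). Compound 4 also stays within the scatter of the piperidin-3-yl compound (a 1.1-fold higher number from compound 1 to compound 4 (0.04 log units; within the scatter)), whereas the step from the piperidin-1-yl compound is large (an at least 75-fold lower number from compound 2 to compound 4 (1.87 log units; beyond the scatter)). Among these compounds, compound 2 remains the only compound at a limit: the limit of > 50000 nM in this assay, at which 1 of the 4 values shown sits.

Open, on these data alone, is how a primary amine or dimethylamino group on the same chain would read in this assay. As far as these compounds go, a morpholin-4-yl group or a longer chain also remains open.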